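Cytotoxicity at the tolerated ceiling: ethoxy for methylsulfanyl

This account rests on a few compounds, and the source may have more. Where it says the series, first, only, none or still open, it means among the compounds named here.

Three compounds share one core and differ only in the group on the six-membered aromatic ring. Compound 1 `Nc1nc(OCC(F)(F)F)c2ncn(/C=C3/CC3(CO)CO)c2n1`, compound 2 `CCCCCCSc1nc(N)nc2c1ncn2/C=C1/CC1(CO)CO` and compound 3 `CSc1nc(N)nc2c1ncn2/C=C1/CC1(CO)CO` were all tested in an ADME assay on BCBL1 cells (Homo sapiens) for cytotoxicity, with a stated time of 7 days; a higher number here means that more compound is tolerated, a lower number that less compound is tolerated. Compound 1 reaches only the limit of > 20000 nM. Compound 2 likewise reaches only the limit of > 20000 nM. Compound 3 also reaches only the limit of > 20000 nM. Because of the limit of > 20000 nM in this assay, at which 3 of the 3 values shown sit, the steps a step that the two limits leave unreadable from compound 1 to compound 2, a step that the two limits leave unreadable from compound 1 to compound 3 and a step that the two limits leave unreadable from compound 2 to compound 3 stay unreadable. Compound 4 `CCOc1nc(N)nc2c1ncn2/C=C1/CC1(CO)CO` carries the change (ethoxy in place of methylsulfanyl on an aromatic carbon). With every measured value sitting at the same limit, nothing points to a readable step, so the expected step is a number no higher from compound 3 to compound 4 (the limit leaves the size open). Compound 4 is therefore expected to give about 20000 nM, within 10000 nM to 40000 nM, most likely again as a limit.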

Compound 4, half-maximal cytotoxic concentration: > 20000 nM
Compound 4: a limit, no number; the forecaster's own chance of this, stated with the estimate: 85%; the middle value lies on the limit itself.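

Compound 4 adds no readable step against compound 1, compound 2 or compound 3, because all four share one ceiling: the limit of > 20000 nM in this assay, at which 4 of the 4 values shown sit. In this assay these compounds leave open whether any of these groups changes the tolerated concentration at all.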